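Urea TRPV1 antagonists: changing the bicyclic aromatic head group

This account rests on a few compounds, and the source may have more. Where it says the series, first, only, none or still open, it means among the compounds named here.

Measured compounds:
Compound 1, `CC1CCN(c2nc(C(F)(F)F)ccc2CNC(=O)Nc2ccc3ccccc3n2)CC1`, "not active" (no number reported)
Compound 2, `CC1CCN(c2nc(C(F)(F)F)ccc2CNC(=O)Nc2ccc3cnncc3c2)CC1`, 8.9 nM

For the measured compounds named here, in an assay on isolated protein for antagonist activity at transient receptor potential cation channel subfamily V member 1 (Homo sapiens), read by FLIPR (a lower number here means a stronger inhibitor, a higher number a weaker inhibitor), compound 2 gives 8.9 nM, the only numerical value in the set. Compound 1, `CC1CCN(c2nc(C(F)(F)F)ccc2CNC(=O)Nc2ccc3ccccc3n2)CC1`, is reported in this assay as "not active" (no number reported), so a change of the bicyclic group on the urea can remove measurable activity altogether. Compound 3, `CC1CCN(c2nc(C(F)(F)F)ccc2CNC(=O)Nc2nccc3ccccc23)CC1`, is still to be measured in this assay. It differs from compound 2 by a group of 10 heavy atoms (9 carbon, 1 nitrogen; one six-membered aromatic ring of carbon only, one six-membered aromatic ring with 1 hetero atom) in place of a group of 10 heavy atoms (8 carbon, 2 nitrogen; one six-membered aromatic ring of carbon only, one six-membered aromatic ring with 2 hetero atoms), on an amide-type nitrogen. Going by the values given here, no measured pair separates this change from others, so its size is not known from the data. Given that compound 1 shows no activity with another bicyclic group in the same place, the expected step of a 28-fold higher number from compound 2 to compound 3 (1.45 log units; beyond the scatter) is toward weaker inhibition, beyond the usual scatter. Compound 3 is therefore estimated at 250 nM in this assay, within a range of 20 nM to 5000 nM.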

Compound 3, inhibition constant: "not active" (no number reported)
No number was reported for compound 3; the estimate stays without a comparison.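

In this assay, for the compounds shown here, compound 3 gives "not active" (no number reported), so no step from compound 2 to it can be read. Nothing shown explains this result. The compounds shown leave open which difference in the bicyclic group separates compound 2 from the two entries without a number.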